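Chloro for Hydrogen: Expected Cytotoxicity of Compound 4

This account rests on a few compounds, and the source may have more. Where it says the series, first, only, none or still open, it means among the compounds named here.

Measured compounds:
Compound 1 `O=c1[nH]nc2n(c1=O)CCN2c1ccccc1`: 30%
Compound 2 `N/N=C1\NCCN1c1ccccc1Cl`: 0%
Compound 3 `N/N=C1\NCCN1c1ccccc1`: 0%

In an ADME assay on Vero cells (Chlorocebus sabaeus) for cytotoxicity, with a stated time of 72 h, tested at 50 ug/mL (a higher number here means a stronger effect of the compound at the concentration tested, a lower number a weaker effect), compound 1 gives 30%. Compound 2 gives 0%, and compound 3 gives 0%. Compound 1 is the highest of the three, and its distance to each of the other two lies beyond the scatter. Compounds 2 and 3 share one core, compound 1 has another; the difference between the two cores is not broken down here.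

Compounds 3 and 2 show one change, (chloro in place of hydrogen on an aromatic carbon), and the step is no change at the digits printed from compound 3 to compound 2 (within the scatter). The same kind of change is now made on compound 1 to give compound 4 `O=c1[nH]nc2n(c1=O)CCN2c1cccc(Cl)c1`: chloro in place of hydrogen on an aromatic carbon. It is the same kind of change but not the same: in compound 2 the chloro sits ortho to a group of 7 heavy atoms, in compound 4 meta to a large group, and the core beneath it is different.

Among the compounds with values here, the one comparison available, from compound 3 to compound 2, sits at the floor of the read-out, so it can show little. Taking it as the only guide, the step from compound 1 to compound 4 is expected to be a number 5 percentage points higher from compound 1 to compound 4 (within the scatter), because the earlier step was no change at the digits printed from compound 3 to compound 2 (within the scatter). Compound 4 is therefore estimated at 35%, with an expected range from 15% to 60%.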

Compound 4, a percentage reported as inhibition, at one concentration (the size of the read-out at that concentration, not a potency): 24%
Estimate against measurement, compound 4: 11 percentage points above, and the stated range covers the measured number.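

In this assay, chloro in place of hydrogen on the aromatic ring of the other core gives a number 6 percentage points lower from compound 1 to compound 4 (within the scatter). Set beside the earlier step, the change reads the same on both cores as far as this measurement can tell: the same change on two cores in this assay, no change at the digits printed (within the scatter) from compound 3 to compound 2 and a number 6 percentage points lower (within the scatter) from compound 1 to compound 4, 6 percentage points apart, within the scatter of two such steps. Within the data shown here, this does not show that chloro is without effect or that it would behave the same way on further cores: there are only two pairs, the read-out comes from one concentration and is not a potency, the chloro does not sit in the same place on the ring in compound 2 as in compound 4, and the first pair starts from compound 3 at 0%.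

The compounds shown leave open how other groups in place of the same hydrogen, such as a methoxy group, an amine or a carboxylic acid, would read on either core. They also leave open whether chloro elsewhere on the ring of compound 1 would give a step of similar size, and what in the core of compound 1 sets it apart from compound 3.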